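The source may report more compounds than this note shows. Statements on the series, on what has been measured and on what is new or still open speak of the compounds shown alone.

Among the compounds with values here, compound 2 `COc1ncc(-c2ccc3ncnc(Nc4cnn(CC(=O)O)c4)c3c2)cc1NS(=O)(=O)c1ccc(F)cc1F` stands at the top of the three numbers so far: in a functional assay on A549 cells (Homo sapiens) for antiproliferative activity, read by sulforhodamine B assay, with a stated time of 72 h (a lower number here means a stronger inhibitor, a higher number a weaker inhibitor), compound 2 gives 5200 nM. Compound 1 `COc1ncc(-c2ccc3ncnc(Nc4ccc(OCCO)cc4)c3c2)cc1NS(C)(=O)=O` gives 5200 nM, level with it at the digits shown, and compound 3 `COC(=O)CCn1cc(Nc2ncnc3ccc(-c4cnc(OC)c(NS(C)(=O)=O)c4)cc23)cn1` gives 2990 nM, the lowest figure, yet only a 1.7-fold lower number from compound 1 to compound 3 (0.24 log units; within the scatter) removed from compound 1, inside the scatter. Compound 1 and compound 2 differ in two places at once, so their values show only that both land on the same figure.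

Compound 4 `COc1ncc(-c2ccc3ncnc(Nc4ccc(OCCO)nc4)c3c2)cc1NS(=O)(=O)c1ccc(F)cc1F` keeps the sulfonamide side of compound 2 and changes the other side: 6-(2-hydroxyethoxy)pyridin-3-yl in place of 1-(carboxymethyl)-1H-pyrazol-4-yl on a nitrogen on an aromatic ring. Within the data shown here, the one measured step that bears on this kind of exchange is the pair compound 1 and compound 3, where a 2-hydroxyethoxy-bearing ring and a substituted pyrazolyl traded places for a 1.7-fold lower number from compound 1 to compound 3 (0.24 log units; within the scatter), within the scatter. Among the measured compounds shown here, the present change runs the opposite way, from a pyrazolyl with a carboxymethyl group to a ring carrying 2-hydroxyethoxy, and no measured pair isolates that exact move with the difluorophenyl sulfonamide held fixed. For compound 4 the expected step is therefore a 1.1-fold higher number from compound 2 to compound 4 (0.02 log units; within the scatter), not beyond the scatter, leaning if anything toward a higher number because compound 1 with the same hydroxyethoxy arm sits at 5200 nM. Compound 4 is estimated at 5500 nM, with a range from 2000 nM to 15000 nM.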

Compound 4, half-maximal inhibitory concentration: 4120 nM
Beside the measured number, compound 4's estimate is 1.3-fold (0.13 log units) above it, within the range that was stated.
By their numbers in this assay, from the lowest: compounds 3, 4, 1 and 2 (each within the scatter of the next).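

With the sulfonamide of compound 2 held fixed, exchanging 1-(carboxymethyl)-1H-pyrazol-4-yl for 6-(2-hydroxyethoxy)pyridin-3-yl on the nitrogen gives, in this assay, a 1.3-fold lower number from compound 2 to compound 4 (0.10 log units; within the scatter), so this five-membered and this six-membered aromatic ring, each with its own arm, cannot be told apart here. The earlier pair, a 1.7-fold lower number from compound 1 to compound 3 (0.24 log units; within the scatter), involved a methyl sulfonamide; the new pair adds a second exchange at this position, on a different sulfonamide, that also stays within the scatter, and neither pair goes against the other. No measurement available here offers an explanation for either step.

Ring and arm change together in both pairs, so their separate contributions remain unresolved, and no single-place pair isolates the sulfonamide exchange. From the compounds shown here alone, it also remains open whether any group on this nitrogen can give a step beyond the scatter, for instance an arm ending in a primary amine, or a longer chain carrying a carboxylic acid on the six-membered ring.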